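The compounds below may be only part of what the source reports. "The series", "measured", "known", "first", "only" and "open" are said of these compounds alone.

Compound 1 `O=C(Nc1ccccc1)c1cc(Oc2ccc(/C=C/c3ccccn3)cc2)ccn1` and compound 2 `COc1ccc(NC(=O)c2cc(Oc3ccc(/C=C/c4ccccn4)cc3)ccn2)cc1` share one core and differ in a single change, (methoxy in place of hydrogen on an aromatic carbon). In a functional assay on HepG2 cells (Homo sapiens) for antiproliferative activity, read by CCK-8 assay, with a stated time of 48 h (a higher number here means a weaker inhibitor, a lower number a stronger inhibitor), compound 1 gives 30200 nM. In this assay compound 2 gives 30000 nM. The step of a 1.0-fold lower number from compound 1 to compound 2 (0.00 log units; within the scatter) shows that the two cannot be told apart on this measure.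

Compound 3 `O=C(Nc1ccccc1)c1cc(Oc2ccc(/C=C/c3ccncc3)cc2)ccn1` differs from compound 1 in the core itself, as pyridin-4-yl in place of pyridin-2-yl on a double-bonded chain carbon bound to a double-bonded chain carbon. In this assay compound 3 reaches only a limit, not a number, reported as > 100000 nM because of the limit of > 100000 nM in this assay, at which 1 of the 3 values shown sits. The step of an at least 3.3-fold higher number from compound 1 to compound 3 (0.51 log units; beyond the scatter) therefore points to a weaker inhibitor.

Compound 4 `COc1ccc(NC(=O)c2cc(Oc3ccc(/C=C/c4ccncc4)cc3)ccn2)cc1` is not yet measured. It stands to compound 3 as compound 2 stands to compound 1: the change is methoxy in place of hydrogen on an aromatic carbon, at the same place in both pairs. Because the same change once gave a 1.0-fold lower number from compound 1 to compound 2 (0.00 log units; within the scatter), the step is expected to be a step that the limit leaves unreadable from compound 3 to compound 4. Compound 4 is thus estimated at 150000 nM in this assay, most likely again only a limit, within a range from 60000 nM to 400000 nM.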

Compound 4, half-maximal inhibitory concentration: > 100000 nM
Compound 4: only a limit was reported (the forecaster's own chance of this, stated with the estimate: 80%); the middle value is on the limit's open side.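

Replacing pyridin-2-yl with pyridin-4-yl on the methoxy-bearing core gives an at least 3.3-fold higher number from compound 2 to compound 4 (0.52 log units; beyond the scatter), so in this assay the swap points the same way on both cores shown, towards a weaker inhibitor: the same change on two cores in this assay, an at least 3.3-fold higher number (0.51 log units; beyond the scatter) from compound 1 to compound 3 and an at least 3.3-fold higher number (0.52 log units; beyond the scatter) from compound 2 to compound 4; the limit leaves it open whether they differ Compound 4 gives > 100000 nM, which is a limit and not a number, so the true size of the swap on this core remains unknown, and the direction is all that carries over. Because compound 3 and compound 4 both stand at a limit, the methoxy step between them cannot be read, and nothing shows whether methoxy again makes no difference on this core: the limit of > 100000 nM in this assay, at which 2 of the 4 values shown sit.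

The compounds shown leave open how the phenyl of the anilino group would respond to substituents other than methoxy, such as a fluorine atom, an amine or a longer alkoxy chain. They also leave open how pyridin-3-yl would compare with pyridin-2-yl and pyridin-4-yl on either core.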